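The source may report more compounds than this note shows. Statements on the series, on what has been measured and on what is new or still open speak of the compounds shown alone.

Measured so far in a functional assay on MCF7 cells (Homo sapiens) for cytotoxicity, read by sulforhodamine B assay, with a stated time of 72 h; a lower number here means a stronger inhibitor, a higher number a weaker inhibitor:
- compound 1 `COc1ncccc1NC(=O)c1cc(-c2ccc(C)cc2)n(-c2ccc3ccccc3n2)n1` gives 30200 nM as its value
- compound 2 `Cc1ccc(-c2cc(C(=O)NCc3cccnc3)nn2-c2ccc3ccccc3n2)cc1` gives 19000 nM as its value

In this assay compound 2 at 19000 nM stands level with compound 1, since their two numbers lie within the scatter of each other. Compound 3 `Cc1ccc(-c2cc(C(=O)Nc3ccncc3Br)nn2-c2ccc3ccccc3n2)cc1` is still unmeasured. It differs from compound 2 as follows: 3-bromopyridin-4-yl in place of (pyridin-3-yl)methyl on an amide-type nitrogen and so carries 3-bromopyridin-4-yl in place of (pyridin-3-yl)methyl on an amide-type nitrogen.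

Within the data shown here, only one measured step bears on this change. That step, a 1.6-fold lower number from compound 1 to compound 2 (0.20 log units; within the scatter), exchanged the group on the same amide-type nitrogen and stayed small. Among the measured compounds shown here, no measured compound carries 3-bromopyridin-4-yl, so this single step is thin guidance, and the bromine has no measured precedent here. No step beyond the scatter is therefore expected, in either direction. The expected step is a 1.2-fold higher number from compound 2 to compound 3 (0.06 log units; within the scatter) and is only an estimate. For compound 3 the estimated value is 22000 nM in this assay, with an expected range from 9000 nM to 50000 nM once it is measured.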

Compound 3, half-maximal inhibitory concentration: 11000 nM
Beside the measured number, compound 3's estimate is 2.0-fold (0.30 log units) above it, and the stated range covers the measured number.
By their numbers in this assay, from the lowest: compounds 3, 2 and 1 (each within the scatter of the next, the first and the last beyond it).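

In this assay, a 1.7-fold lower number from compound 2 to compound 3 (0.24 log units; within the scatter) shows that 3-bromopyridin-4-yl can take the place of (pyridin-3-yl)methyl on the amide-type nitrogen without a change beyond the scatter, so this position accepts a bromine-bearing ring without any loss being seen. Among these compounds, the comparison with the other aryl amide gives a 2.7-fold lower number from compound 1 to compound 3 (0.44 log units; beyond the scatter), the first step at this position to clear the scatter, though it is modest and comes from exchanging 2-methoxypyridin-3-yl for 3-bromopyridin-4-yl. Nothing in hand accounts for either step.

The compounds shown leave open what the bromine itself contributes, as they do not separate it from the ring: a plain pyridin-4-yl, or a chlorine in the bromine's place, on this nitrogen would speak to that. Also open, going by these compounds, is whether a different kind of group on this nitrogen, such as a longer chain ending in an amine or a carboxylic acid, would move the number far from the level of compound 3 at 11000 nM.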